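Swapping a methoxy for isopropyl on the amide nitrogen

The source may hold more compounds than are shown below. What is called first, only, known or untested is meant among the compounds shown, and "the series" means these compounds.

Three compounds share one core and differ at the amide-type nitrogen and its pendant arm. In an assay on HEK293 cells for agonist activity at transient receptor potential cation channel subfamily M member 8 (Homo sapiens), read by fluorescence and calcium flux, with a stated time of 15 min (a lower number here means that less compound is needed, a higher number that more compound is needed for the effect), compound 2 `Cc1ccc(OCC(=O)N(Cc2cccs2)c2ncco2)cc1` gives 0.3 nM, compound 3 `CON(Cc1cccs1)C(=O)COc1ccc(C)cc1` gives 10 nM, and compound 1 `CCN(Cc1c[nH]nn1)C(=O)COc1ccc(C)cc1` gives 31100 nM. For the measured compounds named here, compound 3 thus stands second of the three, far from compound 1 and well apart from compound 2, as the only step drawn shows: a 33-fold higher number from compound 2 to compound 3 (1.52 log units; beyond the scatter). Compound 1 differs from compound 3 in more than one place, so its number is only a reference point.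

Compound 4 `Cc1ccc(OCC(=O)N(Cc2cccs2)C(C)C)cc1` follows from compound 3 through a single change, (isopropyl in place of methoxy on an amide-type nitrogen). Going by the values given here, the one step that bears on this position, from compound 2 to compound 3, was large, and it shows that this nitrogen is sensitive to what sits on it. Among the compounds with values here, no step with an isopropyl is known, so the direction is uncertain; a moderate rise in this assay is expected, a 5.0-fold higher number from compound 3 to compound 4 (0.70 log units; beyond the scatter), with compound 4 estimated at 50 nM, in the range 5 nM to 600 nM.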

Compound 4, half-maximal effective concentration: 70 nM
For compound 4 the middle estimate is 1.4-fold (0.15 log units) below the measured one; the range from low to high includes it.
By their numbers in this assay, from the lowest: compound 2; then compound 3; then compound 4; then compound 1.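

Replacing methoxy with isopropyl on the amide-type nitrogen gives a 7.0-fold higher number from compound 3 to compound 4 (0.85 log units; beyond the scatter) in this assay, so a group of carbon alone, without the oxygen of methoxy, still leaves a measurable effect at this position. The second comparison, a 230-fold higher number from compound 2 to compound 4 (2.37 log units; beyond the scatter), places isopropyl even further from the 1,3-oxazol-2-yl group than methoxy, and among compounds 2, 3 and 4 the two groups without a ring both give much higher numbers than the one with a ring. No measurement is available that explains these differences.

Going by these compounds, it remains open whether the low number of compound 2 is specific to 1,3-oxazol-2-yl or would also appear with another ring, such as phenyl or pyridin-2-yl. On these data alone, how a longer chain, such as n-butyl, or an amine-bearing chain would behave on this nitrogen also remains open.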